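Trifluoromethyl moved to a new ring position on the lactam

The source may report more compounds than this note shows. Statements on the series, on what has been measured and on what is new or still open speak of the compounds shown alone.

Compound 2 `O=C1C=CCC(/C=C/c2ccccc2)N1` gives 929 uM in a functional assay on NCI-H460 cells (Homo sapiens) for inhibition, read by sulforhodamine B assay, with a stated time of 48 h (a lower number here means a stronger inhibitor of growth, a higher number a weaker inhibitor of growth), and stands highest of the three numbers recorded. The nearest is compound 1 `O=C1C=CCC(/C=C/c2ccccc2C(F)(F)F)O1`, which gives 242 uM in this assay, and the furthest is compound 3 `O=C1C=CCC(/C=C/c2ccccc2C(F)(F)F)N1`, which gives 195 uM. Compound 4 `O=C1C=CCC(/C=C/c2ccc(C(F)(F)F)cc2)N1` has not been measured yet. It differs from compound 2 in one place: trifluoromethyl in place of hydrogen on an aromatic carbon.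

Within the data shown here, the one measured step that bears on this change is the one from compound 2 to compound 3, where the same group enters at another carbon of the same ring: a 4.8-fold lower number from compound 2 to compound 3 (0.68 log units; beyond the scatter). Whether the new position carries the same gain is not shown by any measured pair, so the size of the step is taken with some caution. The expected step is a 3.6-fold lower number from compound 2 to compound 4 (0.55 log units; beyond the scatter) in this assay. Compound 4 is therefore estimated at 260 uM, with a range from 100 uM to 650 uM.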

Compound 4, concentration for growth inhibition (reported as GI): 150 uM
Compound 4: middle estimate off by 1.7-fold (0.24 log units), on the high side; low and high end bracket the measured number.
By their numbers in this assay, from the lowest: compounds 4, 3 and 1 (each within the scatter of the next); then compound 2.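

In this assay trifluoromethyl also lowers the number on the aromatic carbon para to a group of 9 heavy atoms: the step is a 6.2-fold lower number from compound 2 to compound 4 (0.79 log units; beyond the scatter) and, taken with the step to compound 3, it shows that the gain is not tied to a single carbon of this ring. Compound 3 at 195 uM and compound 4 at 150 uM lie within the scatter of each other, so these numbers do not tell the two positions apart. No measurement at hand accounts for the gain at either position.

Still open, as far as these compounds go, is whether a methoxy group, a nitrile or a carboxylic acid on this carbon would lower the number as trifluoromethyl does. Also open, from the compounds shown here alone, is whether the core of compound 1 would respond in the same way to trifluoromethyl at this position.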